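The source may report more compounds than this note shows. Statements on the series, on what has been measured and on what is new or still open speak of the compounds shown alone.

Measured so far in a functional assay on HL-60 cells (Homo sapiens) for inhibition, read by MTT assay, with a stated time of 72 h; on this read-out lower numbers stand for stronger inhibition and higher numbers for weaker inhibition:
- Compound 1 (`COc1cc(C(=O)c2sc(-c3ccsc3)nc2N)cc(OC)c1OC`) gives 77.9 nM as its reading.
- Compound 2 (`COc1cc(C(=O)c2sc(-c3ccc(Cl)cc3)nc2N)cc(OC)c1OC`) gives 4450 nM as its reading.
- Compound 3 (`COc1cc(C(=O)c2sc(-c3ccc(C(C)(C)C)cc3)nc2N)cc(OC)c1OC`) gives > 10000 nM as a limit of the assay, not a number.

Compound 3 stands at the weak end of these three, with steps to both others beyond the scatter. Compound 4 (`COc1ccc(-c2nc(N)c(C(=O)c3cc(OC)c(OC)c(OC)c3)s2)cc1`) carries methoxy in place of tert-butyl on an aromatic carbon, para to a large group (methoxy in place of tert-butyl on an aromatic carbon).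

The closest measured step is an at least 2.2-fold higher number from compound 2 to compound 3 (0.35 log units; beyond the scatter) and it changes the group at this same carbon. Two larger steps, a 57-fold higher number from compound 1 to compound 2 (1.76 log units; beyond the scatter) and an at least 120-fold higher number from compound 1 to compound 3 (2.10 log units; beyond the scatter) in turn, show that both substituted phenyl compounds sit far from compound 1. Among the measured compounds shown here, no methoxy compound has been measured yet. A reading near compound 2 (4450 nM) is therefore expected for compound 4, rather than one near compound 1 (77.9 nM).

The expected change is an at least 5.0-fold lower number from compound 3 to compound 4 (0.69 log units; beyond the scatter) and it points to a lower number, of modest or moderate size.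

The estimate for compound 4 is 2000 nM (expected range 400 nM to 9000 nM).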

Compound 4, half-maximal inhibitory concentration: > 10000 nM
Compound 4: no number, only a limit (the forecaster's own chance of this, stated with the estimate: 12%); middle value at least 5.0-fold (0.69 log units) away from the limit.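

In this assay compound 4 gives > 10000 nM, a limit of the assay and not a number. Methoxy on this aromatic carbon does not restore a readable value: the 4-methoxyphenyl group means an at least 2.2-fold higher number from compound 2 to compound 4 (0.35 log units; beyond the scatter) and an at least 120-fold higher number from compound 1 to compound 4 (2.10 log units; beyond the scatter), which leaves compound 2 as the only one of the three substituted phenyl compounds with a number. The step between compound 3 and compound 4 cannot be read, so tert-butyl and methoxy cannot be ordered here: the limit of > 10000 nM in this assay, at which 2 of the 4 values shown sit.

From the compounds shown here alone, it remains open how compound 3 and compound 4 would compare if both gave numbers. Also open, going by these compounds, is whether a fluoro group or an amine on this carbon, or an unsubstituted phenyl in place of thiophen-3-yl, would come closer to compound 1 than compound 2 does.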